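Methyl on the exocyclic alkene of a diarylethylene

The source may hold more compounds than are shown below. What is called first, only, known or untested is meant among the compounds shown, and "the series" means these compounds.

Measured compounds:
compound 1 `C=C(c1ccc(OC)c(N)c1)c1ccc(OC)c(OCC)c1` — 38 nM
compound 2 `COc1ccc(C(=CC#N)c2ccc(OC)c(OC)c2)cc1OC` — 140 nM

In a functional assay on HCT-116 cells (Homo sapiens) for cytotoxicity, read by scintillation counting and thymidine incorporation, with a stated time of 72 h (on this read-out lower numbers stand for stronger inhibition and higher numbers for weaker inhibition), compound 1 gives 38 nM, the lowest of the two numbers shown, and compound 2 gives 140 nM, a gap beyond the scatter. Compound 3 `CC=C(c1ccc(OC)c(N)c1)c1ccc(OC)c(OCC)c1` has not been measured. It differs from compound 1 as follows: methyl in place of hydrogen on a double-bonded chain carbon bound to a double-bonded chain carbon. Among the compounds with values here, no measured pair shows this change alone. A modest weakening is expected, on the grounds that compound 2 carries a substituted alkene carbon and gives 140 nM. For compound 3 the expected value in this assay is 100 nM, between 25 nM and 500 nM, a step of a 2.6-fold higher number from compound 1 to compound 3 (0.42 log units; beyond the scatter).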

Compound 3, half-maximal inhibitory concentration: 110 nM
For compound 3 the middle estimate is 1.1-fold (0.04 log units) below the measured one, and the stated range covers the measured number.
By their numbers in this assay, from the lowest: compound 1; then compounds 3 and 2 (each within the scatter of the next).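

In this assay, methyl in place of hydrogen on a double-bonded chain carbon bound to a double-bonded chain carbon gives a 2.9-fold higher number from compound 1 to compound 3 (0.46 log units; beyond the scatter), the only single-place step shown. This position therefore accepts the added methyl with a modest loss, and the hydrogen gives the lower number. No measurement shown here accounts for this step.

Going by these compounds, whether ethyl, a longer chain or hydroxymethyl at this carbon would raise the number further remains open. So does whether the methyl step would hold with other groups on the core of compound 1.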